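Extending the Ester Chain: What Compound 4 Should Tolerate

A few compounds are considered here, and "the series" means these few. Any claim that something is new, unique, unknown or untested is made for them only; others in the source may bear on it.

compound 1, `CCC(=O)Oc1[nH]c2ccccc2c1Cc1c(OC(C)=O)ccc2ccc(=O)oc12`: 67000 nM
compound 2, `CC(=O)Oc1ccc2ccc(=O)oc2c1Cc1c(-c2ccccc2)[nH]c2ccccc12`: > 100000 nM
compound 3, `CC(=O)Oc1ccc2ccc(=O)oc2c1Cc1c(C)[nH]c2ccccc12`: 62000 nM

In an ADME assay on MT4 cells (Homo sapiens) for cytotoxicity, read by MTT assay, with a stated time of 96 h (a lower number here means that less compound is tolerated, a higher number that more compound is tolerated), compound 1 gives 67000 nM and compound 3 gives 62000 nM; the two lie within the scatter of each other, as a 1.1-fold lower number from compound 1 to compound 3 (0.03 log units; within the scatter) shows. For compound 2 the assay reports only a limit, > 100000 nM, the limit described by the limit of > 100000 nM in this assay, at which 1 of the 3 values shown sits. The steps involving compound 2, an at least 1.4-fold higher number from compound 1 to compound 2 (0.17 log units; that floor lies within the scatter) and an at least 1.6-fold lower number from compound 2 to compound 3 (0.20 log units; that floor lies within the scatter), have floors that likewise sit within the scatter. Compound 3 thus stands alongside compound 1, with compound 2 known only as a limit.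

Compound 4 `Cc1[nH]c2ccccc2c1Cc1c(OC(=O)CCCC(=O)O)ccc2ccc(=O)oc12` differs from compound 3 by 2-carboxyethyl in place of hydrogen on a saturated chain carbon bound to a carbonyl carbon. For the measured compounds named here, none of the measured steps touches this acetyl group; all three change the substituent on an aromatic carbon of the shared core, and none of them moved the number beyond the scatter. On that footing compound 4 is expected to sit close to compound 3, with the step of a 1.2-fold higher number from compound 3 to compound 4 (0.08 log units; within the scatter) estimated to remain within the scatter, leaning if anything toward a higher number. Compound 4 is therefore estimated at 75000 nM, within a range from 38000 nM to 150000 nM, and there is a fair chance that the assay again reports only a limit.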

Compound 4, half-maximal cytotoxic concentration: 27000 nM
Compound 4: the middle estimate sits 2.8-fold (0.44 log units) above what was measured; measured number outside the range, below it.
By their numbers in this assay, from the lowest: compound 4; then compounds 3 and 1 (each within the scatter of the next). At a limit, above all of these: compound 2.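

In this assay, the change of 2-carboxyethyl in place of hydrogen on a saturated chain carbon bound to a carbonyl carbon gives a 2.3-fold lower number from compound 3 to compound 4 (0.36 log units; beyond the scatter), so that less compound is tolerated. The earlier steps shown here, all on an aromatic carbon, stayed within the scatter or had floors that lay within it, which makes this the first place where a change clearly moves the number, though the step is modest and rests on a single pair. Nothing among the data shown accounts for this step.

The compounds shown leave open whether the lower number goes with the carboxylic acid at the end of the chain or with the longer chain itself, a question that a chain ending in a methyl group, an amine or a methyl ester in place of the acid would bear on. Also open, on these data alone, is whether acetyl extended to (3-carboxypropyl)carbonyl would shift the number in the same way when the aromatic carbon carries phenyl or propanoyloxy rather than methyl.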